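Swapping isobutylamino for diethylamino in compound 3

A few compounds are considered here, and "the series" means these few. Any claim that something is new, unique, unknown or untested is made for them only; others in the source may bear on it.

Going by the values given here, in a functional assay on HCT-116 cells (Homo sapiens) for antiproliferative activity, read by MTT assay, with a stated time of 72 h (a lower number here means a stronger inhibitor, a higher number a weaker inhibitor), three compounds have numbers so far. Compound 1 (`CC(C)NC(=N)NC(=N)Nc1ccc(C(F)(F)F)cc1`) gives 4800 nM, and compound 2 (`CC(C)CNC(=N)NC(=N)Nc1ccc(C(F)(F)F)cc1`) gives 3500 nM. Compound 3 (`CC(C)CNC(=N)NC(=N)Nc1ccc(F)c(F)c1`) gives 29700 nM, the highest number of the three and beyond the scatter from both of the others, which makes it the weakest inhibitor in this small set.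

Compound 4 (`CCN(CC)C(=N)NC(=N)Nc1ccc(F)c(F)c1`) holds the same atoms as compound 3, joined differently, with diethylamino in place of isobutylamino on a carbon with a double bond to nitrogen.

Among the compounds with values here, only one measured step offers any guidance here: a 1.4-fold lower number from compound 1 to compound 2 (0.14 log units; within the scatter), which puts isobutyl in place of isopropyl on an amine nitrogen and stays within the scatter. Within the data shown here, that step is an imperfect guide, since no measured pair contains diethylamino, and the data cannot show what this particular exchange does. Among the measured compounds shown here, with that small step as the only evidence, no shift beyond the scatter is expected in this assay, and no direction can be favoured with confidence.

The expected step is a 1.2-fold lower number from compound 3 to compound 4 (0.07 log units; within the scatter), which would lie within the scatter. For compound 4 the estimated value is 25000 nM, with an expected range from 10000 nM to 60000 nM.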

Compound 4, half-maximal inhibitory concentration: 39400 nM
Beside the measured number, compound 4's estimate is 1.6-fold (0.20 log units) below it, within the range that was stated.
By their numbers in this assay, from the lowest: compounds 2 and 1 (each within the scatter of the next); then compounds 3 and 4 (each within the scatter of the next).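

In this assay, exchanging isobutylamino for diethylamino gives a 1.3-fold higher number from compound 3 to compound 4 (0.12 log units; within the scatter). The two groups have the same count of heavy atoms, but isobutylamino has one hydrogen-bond donor and diethylamino has none, so for this one pair, removing that donor from the group on a carbon with a double bond to nitrogen leaves the two numbers within the scatter of each other. The earlier step between isopropyl and isobutyl could not show this, since the donor count on that amine nitrogen is the same on both sides of that step, and nothing measured here bears on the reason for the new result.

This reading rests on a single pair, so the compounds shown leave open whether diethylamino would behave the same way on the trifluoromethyl-bearing core of compound 2. They also leave open what happens at this place with a smaller dimethylamino group, or with a ring amine such as pyrrolidine or morpholine, which would show whether the position tolerates other shapes of amine.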